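This account rests on a few compounds, and the source may have more. Where it says the series, first, only, none or still open, it means among the compounds named here.

Notes on the series: in a functional assay on OVCAR-3 cells (Homo sapiens) for cytotoxicity, read by sulforhodamine B assay (a lower number here means a stronger inhibitor of growth, a higher number a weaker inhibitor of growth), compound 1 `CC1=CC[C@@H]([C@@](C)(O)CCCC(C)(C)NC(=S)N/N=C\c2ccccc2)CC1` gives 12900 nM, compound 2 `CC1=CC[C@@H]([C@@](C)(O)CCCC(C)(C)NC(=S)N/N=C\c2ccc(C)cc2)CC1` gives 11800 nM and compound 3 `CC1=CC[C@@H]([C@@](C)(O)CCCC(C)(C)NC(=S)N/N=C\c2ccccc2[N+](=O)[O-])CC1` gives 16200 nM. Compound 2 thus stands within the scatter of both other compounds. Compound 4 `CC1=CC[C@@H]([C@@](C)(O)CCCC(C)(C)NC(=S)N/N=C\c2ccccc2Cl)CC1` differs from it as follows: 2-chlorophenyl in place of 4-methylphenyl on a carbon with a double bond to nitrogen. The closest measured change replaces the same 4-methylphenyl with 2-nitrophenyl, a 1.4-fold higher number from compound 2 to compound 3 (0.14 log units; within the scatter). The ring changes a 1.1-fold lower number from compound 1 to compound 2 (0.04 log units; within the scatter) and a 1.3-fold higher number from compound 1 to compound 3 (0.10 log units; within the scatter) also bear on it. All three lie within the scatter, so no step beyond the scatter is expected in this assay. The expected change is a 1.1-fold higher number from compound 2 to compound 4 (0.06 log units; within the scatter). The estimate for compound 4 is 13500 nM, with an expected range of 8000 nM to 22000 nM.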

Compound 4, concentration for total growth inhibition: > 100000 nM
Compound 4 was reported as a limit (the forecaster's own chance of this, stated with the estimate: 3%); middle value at least 7.4-fold (0.86 log units) away from the limit.
By their numbers in this assay, from the lowest: compounds 2, 1 and 3 (each within the scatter of the next). At a limit, above all of these: compound 4.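

In this assay the value of compound 4 is a limit, not a number: the limit of > 100000 nM in this assay, at which 1 of the 4 values shown sits.

Chloro in place of hydrogen gives an at least 7.7-fold higher number from compound 1 to compound 4 (0.88 log units; beyond the scatter), and 2-chlorophenyl in place of 4-methylphenyl gives an at least 8.4-fold higher number from compound 2 to compound 4 (0.92 log units; beyond the scatter). Chloro in place of nitro gives an at least 6.1-fold higher number from compound 3 to compound 4 (0.79 log units; beyond the scatter), so this ring is not indifferent to its substituent, as the methyl and nitro compounds alone had suggested.

Going by these compounds, how far compound 4 lies past the limit stays open. So does whether fluoro, bromo or an amine on this ring would track chloro or nitro.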